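Working notes on the aryl change from compound 2 to compound 3

The compounds below may be only part of what the source reports. "The series", "measured", "known", "first", "only" and "open" are said of these compounds alone.

Measured so far in a functional assay on HEK293 cells with D(4) dopamine receptor (Homo sapiens) as the target, read by FLIPR; a higher number here means a larger maximal response, a lower number a smaller maximal response:
compound 1, `O/N=C(\CCN1CCN(c2ccccn2)CC1)c1cccc(F)c1`, gives 72%
compound 2, `Cc1cc(C)cc(/C(CCN2CCN(c3ccccn3)CC2)=N/O)c1`, gives 55%

Compound 2 holds the lower of the two numbers; its nearest neighbour is compound 1, and the step of a number 17 percentage points lower from compound 1 to compound 2 (beyond the scatter) is beyond the scatter. Compound 3, `Cc1ccc(O)c(/C(CCN2CCN(c3ccccn3)CC2)=N/O)c1`, has not yet been measured. It differs from compound 2 as follows: 2-hydroxy-5-methylphenyl in place of 3,5-dimethylphenyl on a carbon with a double bond to nitrogen. For the measured compounds named here, the only measured step that bears on this change is the one on the same carbon, a number 17 percentage points lower from compound 1 to compound 2 (beyond the scatter), which was modest and ran downward when the fluorine-bearing ring gave way to the dimethyl ring. Compound 3 keeps one methyl and brings in a hydroxyl; nothing measured here tells which way that points. A step of modest size, of unsettled direction, is expected: a number 5 percentage points higher from compound 2 to compound 3 (within the scatter). Compound 3 is therefore estimated at 60%, within 40% to 80%.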

Compound 3, largest response reached (reported as efficacy), in percent of the reference or control that the assay uses: 73%
Compound 3: middle estimate off by 13 percentage points, on the low side; low and high end bracket the measured number.
By their numbers in this assay, from the lowest: compound 2; then compounds 1 and 3 (each within the scatter of the next).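

At the carbon with a double bond to nitrogen, the aryl group can move the maximal response in either direction in this assay: 2-hydroxy-5-methylphenyl in place of 3,5-dimethylphenyl gives a number 18 percentage points higher from compound 2 to compound 3 (beyond the scatter), opposite in direction to the earlier a number 17 percentage points lower from compound 1 to compound 2 (beyond the scatter). Set against 3-fluorophenyl, the same 2-hydroxy-5-methylphenyl group gives a number 1 percentage points higher from compound 1 to compound 3 (within the scatter), so two differently substituted rings cannot be told apart at this position, and among these compounds only the 3,5-dimethylphenyl group sits apart from the others. Nothing on hand accounts for these steps.

As far as these compounds go, the step to compound 3 changes the hydroxyl and the methyl pattern together, and the share of the hydroxyl alone stays open. Also open, from the compounds shown here alone, is whether a methoxy group or an amine in place of that hydroxyl would hold the response of compound 3.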